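The source may hold more compounds than are shown below. What is called first, only, known or untested is meant among the compounds shown, and "the series" means these compounds.

The shared core carries a double-bonded chain, and the group at the far end of that chain is what changes across the set. Compound 1 `COc1ccc(C(=O)/C=C/c2ccc(F)cc2)c2c1C=CC(C)(C)O2` is the 4-fluorophenyl member. In a functional assay on K562 cells (Homo sapiens) for antiproliferative activity, read by MTT assay, with a stated time of 24 h (on this read-out higher numbers stand for weaker inhibition and lower numbers for stronger inhibition), compound 1 returns only a limit, > 10000 nM, and no number. Compound 3 `COc1ccc(C(=O)/C=C/c2cccc3ccccc23)c2c1C=CC(C)(C)O2` likewise stops at a limit, > 10000 nM, in this assay. Compound 2 `COc1ccc(C(=O)/C=C/c2ccc3ccccc3n2)c2c1C=CC(C)(C)O2` is the member that gives a number, 3020 nM, in this assay. Compound 1 thus sits at the limit of > 10000 nM in this assay, at which 2 of the 3 values shown sit, alongside compound 3, and against compound 2 all that can be said is that compound 2 yields a number where compound 1 does not.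

Compound 4 `COc1ccc(C(=O)/C=C/c2ccc(O)c(Br)c2)c2c1C=CC(C)(C)O2` is still to be measured. It differs from compound 1 by 3-bromo-4-hydroxyphenyl in place of 4-fluorophenyl on a double-bonded chain carbon bound to a double-bonded chain carbon. Going by the values given here, no measured pair in the set follows a step of this kind, so the direction is a guess: a shift toward stronger inhibition, into the region where a number is reported, is expected for a 3-bromo-4-hydroxyphenyl member, while a repeat at the limit remains quite possible. For compound 4 a value near 7000 nM is expected, within 2000 nM to 20000 nM, which amounts to an expected step of an at least 1.4-fold lower number from compound 1 to compound 4 (0.15 log units; that floor lies within the scatter).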

Compound 4, half-maximal inhibitory concentration: > 10000 nM
Compound 4: a limit, no number; the forecaster's own chance of this, stated with the estimate: 45%; at least 1.4-fold (0.15 log units) between middle value and limit.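

In this assay compound 4 gives > 10000 nM, a limit and not a number. Compound 1 also gives only a limit, so no step can be read between compound 1 and compound 4. The compounds shown leave open whether 3-bromo-4-hydroxyphenyl in place of 4-fluorophenyl changes inhibition at all, and in which direction.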